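The compounds below may be only part of what the source reports. "The series", "measured", "known", "first", "only" and "open" are said of these compounds alone.

Compound 1 `COc1ccc(-c2nc(C)c(C(=O)CSc3nc(N)c(C#N)c(-c4ccc(Cl)cc4)n3)s2)cc1` and compound 2 `COc1ccc(-c2nc(C)c(C(=O)CSc3nc(N)c(C#N)c(-c4ccccc4)n3)s2)cc1` share one core; compound 3 `Cc1nc(-c2ccccc2)sc1C(=O)CSc1nc(-c2cccc(Cl)c2)c(C#N)c(=O)[nH]1` and compound 4 `Cc1nc(-c2ccccc2)sc1C(=O)CSc1nc(-c2ccccc2)c(C#N)c(=O)[nH]1` share another, and the difference between the two cores is not broken down here. In a functional assay on U-87MG ATCC cells for antiproliferative activity against U-87 MG (Homo sapiens), read by MTT assay, with a stated time of 48 h, tested at 5 uM (a higher number here means a weaker effect of the compound at the concentration tested, a lower number a stronger effect), compound 1 gives 51.4%, compound 2 gives 61.8% and compound 3 gives 86.9%. The change hydrogen in place of chloro on an aromatic carbon made a step of a number 10.4 percentage points higher from compound 1 to compound 2 (beyond the scatter). The change from compound 3 to compound 4, (hydrogen in place of chloro on an aromatic carbon), is the same kind of change, but the place differs: in the first pair the chloro sits para to a large group, in the second meta to a large group. Because the step of a number 10.4 percentage points higher from compound 1 to compound 2 (beyond the scatter) was modest, compound 4 is expected to show a step of about a number 7.1 percentage points higher from compound 3 to compound 4 (within the scatter) in this assay. Compound 4 is therefore estimated at 94%, likely between 82% and 104%.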

Compound 4, a percentage reported as activity, at one concentration (the size of the read-out at that concentration, not a potency): 92.1%
Compound 4: middle estimate off by 1.9 percentage points, on the high side; the measured number falls inside the stated range.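

Replacing the chloro with hydrogen, 3-chlorophenyl to phenyl, gave a number 5.2 percentage points higher from compound 3 to compound 4 (within the scatter) in this assay, and the size of this step agrees with the earlier one on the other core: the same change on two cores in this assay, a number 10.4 percentage points higher (beyond the scatter) from compound 1 to compound 2 and a number 5.2 percentage points higher (within the scatter) from compound 3 to compound 4, 5.2 percentage points apart, within the scatter of two such steps. Within this series the change therefore carries from one core to the other without a step size that can be told apart, but this rests on only one pair per core. The chloro also sits in a different place in each pair, so the effect of the core cannot be separated from that of the place.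

Going by these compounds, whether a fluoro or bromo in the same place would behave like the chloro remains open. So does how an amine on that ring would read.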